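Dropping a Chloro on the Sulfonyl Aryl: Cytotoxicity Outlook

This account rests on a few compounds, and the source may have more. Where it says the series, first, only, none or still open, it means among the compounds named here.

Compound 1: `COc1ccc([C@H]2CC(=O)N(c3cccc(N(C)C)c3)C2)cc1OC1CCCC1` — > 10000 nM
Compound 2: `COc1ccc([C@H]2CC(=O)N(c3cccc(NS(=O)(=O)c4cccc(OC(F)(F)F)c4)c3)C2)cc1OC1CCCC1` — > 10000 nM
Compound 3: `COc1ccc([C@H]2CC(=O)N(c3cccc(NS(=O)(=O)c4cccc(Cl)c4C)c3)C2)cc1OC1CCCC1` — > 10000 nM

All three values come from a functional assay on HEK293 cells (Homo sapiens) for cytotoxicity (on this read-out higher numbers stand for lower toxicity in this test and lower numbers for higher toxicity in this test), and each is a limit of the assay rather than a measured number. Compound 1 gives > 10000 nM as such a limit. Compound 2 likewise gives a limit, > 10000 nM. Compound 3 stands at the same limit, > 10000 nM, so its place on the numbers shown is known only as a bound. For that reason the two steps into compound 3, a step that the two limits leave unreadable from compound 1 to compound 3 and a step that the two limits leave unreadable from compound 2 to compound 3, cannot be read in size at all.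

Compound 4 is `COc1ccc([C@H]2CC(=O)N(c3cccc(NS(=O)(=O)c4ccccc4C)c3)C2)cc1OC1CCCC1`. It differs from compound 3 in one place: hydrogen in place of chloro on an aromatic carbon. For the measured compounds named here, no measured step leading to compound 3 has a readable size, so none can be carried over to this change; the only evidence bearing on it is the limit of > 10000 nM in this assay, at which 3 of the 3 values shown sit. Compound 4 is therefore expected to sit at that same limit again in this assay, giving an estimated 15000 nM within 8000 nM to 40000 nM. The step this estimate implies is expected to be a step that the limit leaves unreadable from compound 3 to compound 4, nothing beyond the scatter.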

Compound 4, half-maximal cytotoxic concentration: > 10000 nM
Compound 4 ended at the assay's limit; the forecaster's own chance of this, stated with the estimate: 85%; the middle value lies beyond the limit too.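

In this assay, for the compounds shown here, compound 4 gives > 10000 nM, a limit of the assay, so no step from compound 1, compound 2 or compound 3 to compound 4 can be read in size. All the values remain limits: the limit of > 10000 nM in this assay, at which 4 of the 4 values shown sit.

The compounds shown leave open where each one truly stands beyond that limit, and whether hydrogen in place of chloro changes cytotoxicity at all.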